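A few compounds are considered here, and "the series" means these few. Any claim that something is new, unique, unknown or untested is made for them only; others in the source may bear on it.

Working notes on the sulfonamide series in a functional assay on DLD-1 cells (Homo sapiens) for antiproliferative activity, read by CellTiter-Glo, with a stated time of 72 h; a lower number here means a stronger inhibitor, a higher number a weaker inhibitor.

Of the compounds shown here, three carry numbers so far. Compound 1 `CC1CCN(C2CCN(S(=O)(=O)c3cccc(-c4ccc(Cl)cc4)c3)CC2)CC1` gives 15 nM in this assay. Compound 3 `COc1cc(C)c(S(=O)(=O)N2CCC(N3CCC(C)CC3)CC2)cc1C(C)C` gives 3 nM, and compound 2 `Cc1cc(C)c(S(=O)(=O)N2CCC(N3CCN(C)CC3)CC2)c(C)c1` gives 1100 nM. On these three numbers compound 1 sits in the middle: compound 3 stands at a lower number and compound 2 at a much higher number, and both gaps lie beyond the usual scatter. For the measured compounds named here, none of the measured pairs differ in a single place, so no step between measured compounds is available to calibrate the change that follows.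

Compound 4 `CC1CCN(C2CCN(S(=O)(=O)c3cccc(-c4ccccc4)c3)CC2)CC1` is the next compound to be measured in this assay. It differs from compound 1 in one place: hydrogen in place of chloro on an aromatic carbon. Going by the values given here, no measured pair shows this change, so the expectation rests on compound 1 alone. The step from compound 1 to compound 4 is expected to be a modest loss, a 2.7-fold higher number from compound 1 to compound 4 (0.43 log units; beyond the scatter), that is a somewhat higher number, though it may fall within the scatter. For compound 4 the estimate in this assay is 40 nM, with a range from 12 nM to 150 nM.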

Compound 4, half-maximal inhibitory concentration: 2 nM
The estimate for compound 4 lay 20-fold (1.30 log units) above the measured number; measured number outside the range, below it.
By their numbers in this assay, from the lowest: compounds 4 and 3 (each within the scatter of the next); then compound 1; then compound 2.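

In this assay, the change from 4-chlorophenyl to phenyl gives a 7.5-fold lower number from compound 1 to compound 4 (0.88 log units; beyond the scatter), so on this pair the chloro on this aromatic carbon, para to a large group, is not needed for a low number and hydrogen serves better. For the compounds shown here, this is the first step that changes one place only, and it gives this position a direction that the earlier compounds, which differ in more than one place, could not give. Nothing at hand bears on the reason for this step.

The compounds shown leave open how other groups at this position, such as fluoro, methoxy, an amine or a carboxylic acid, would compare with hydrogen and chloro. They also leave open whether hydrogen in place of chloro would move the number the same way on a different core.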